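Chain-terminus variation on a hydroxyacetophenone series

This account rests on a few compounds, and the source may have more. Where it says the series, first, only, none or still open, it means among the compounds named here.

Measured compounds in an assay on isolated protein for inhibition of leukotriene B4 receptor 1 (Homo sapiens), tested at 10 uM; on this read-out lower numbers stand for less inhibition and higher numbers for more inhibition at the one concentration tested (going by the name of the read-out):
compound 1, `CCc1cc(C(C)=O)c(O)cc1OCCCCC#N`, 92%
compound 2, `CCc1cc(C(C)=O)c(O)cc1OCCCCCC(C)(C)C(=O)O`, 104%
compound 3, `CCc1cc(C(C)=O)c(O)cc1OCCCCCC(C)(C)c1nnn(C)n1`, 95%

All three measured compounds give high inhibition at the single concentration. Compound 3 stands second of the three; its nearest neighbour is compound 1, its furthest compound 2, and both gaps are within the scatter. The two measured steps are a number 12 percentage points higher from compound 1 to compound 2 (beyond the scatter) and a number 9 percentage points lower from compound 2 to compound 3 (within the scatter), so neither change at the chain terminus has moved the read-out far.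

Compound 4, `CCc1cc(C(C)=O)c(O)cc1OCCCCCCSC`, is the next compound in this series. The change from compound 3: (methylsulfanyl)methyl in place of 1-methyl-1-(2-methyl-2H-tetrazol-5-yl)ethyl on a saturated chain carbon, five bonds along the chain from an oxygen on an aromatic ring. Among the measured compounds shown here, no measured step exchanges a tetrazolyl-bearing group for a sulfur-bearing one, so no step bears directly on it. The closest indication is compound 1, which with a nitrile at the chain terminus gives 92%, showing that a terminus other than carboxy or tetrazolyl still gives high inhibition.

In this assay compound 4 is therefore expected to remain within or slightly below the measured range, with an estimated step of a number 10 percentage points lower from compound 3 to compound 4 (within the scatter). The estimate for compound 4 is 85%, in the range 60% to 100%.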

Compound 4, a percentage reported as inhibition, at one concentration (the size of the read-out at that concentration, not a potency): 71%
The estimate for compound 4 lay 14 percentage points above the measured number; low and high end bracket the measured number.
By their numbers in this assay, from the lowest: compound 4; then compounds 1, 3 and 2 (each within the scatter of the next, the first and the last beyond it).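

In this assay, this position is not indifferent to the terminal group: the (methylsulfanyl)methyl group brings a number 24 percentage points lower from compound 3 to compound 4 (beyond the scatter), and the drop is larger against the carboxylic acid, at a number 33 percentage points lower from compound 2 to compound 4 (beyond the scatter). The nitrile comparison gives a number 21 percentage points lower from compound 1 to compound 4 (beyond the scatter), so among these compounds a terminus lacking both the carboxy and the tetrazolyl group can hold the read-out high, as in compound 1, or lose part of it, as in compound 4. Nothing shown accounts for the drop.

The exchange from compound 3 removes the tetrazole ring and the two chain methyl groups and brings in sulfur all at once, leaving open which of these goes with the lower number. A terminal methoxy group, a plain alkyl chain of the same length or a primary amine would help separate these.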